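Inverting one ring stereocentre in the shared core

The source may hold more compounds than are shown below. What is called first, only, known or untested is meant among the compounds shown, and "the series" means these compounds.

Two measured compounds open this account. Compound 1 `C[C@@H]1NC(=O)C2(Cc3ccccc3C2)NC(=O)[C@H](CCCCCSSc2ccccn2)NC(=O)[C@H]2CCCN2C1=O` and compound 2 `C[C@@H]1NC(=O)[C@@]2(CCc3ccccc32)NC(=O)[C@H](CCCCCSSc2ccccn2)NC(=O)[C@H]2CCCN2C1=O` share the same core and side chain. In an in vitro assay on 293T cells for inhibition of histone deacetylase 4 (Homo sapiens) (on this read-out lower numbers stand for stronger inhibition and higher numbers for weaker inhibition), compound 1 gives 1.6 nM, and in the same assay compound 2 gives 2.4 nM. Compound 2 holds the higher of the two numbers, but compound 1 sits only a step away that falls within the scatter, so the two values show no order between them.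

Compound 3 `C[C@@H]1NC(=O)[C@]2(CCc3ccccc32)NC(=O)[C@H](CCCCCSSc2ccccn2)NC(=O)[C@H]2CCCN2C1=O` is not yet measured. Compared with compound 2, (the two compounds have the same atoms and bonds and differ only in configuration as drawn: 1 of 4 stereo elements differ; a stereocentre at a saturated ring carbon is drawn S in compound 2 and R in compound 3). Among the measured compounds shown here, no measured pair here isolates the effect of such an inversion, so nothing in the data fixes the size or sign of the step, and the estimate must stay broad. In this assay compound 3 is expected to give 6 nM, within a range from 1.5 nM to 40 nM. That expectation corresponds to a step of a 2.5-fold higher number from compound 2 to compound 3 (0.40 log units; beyond the scatter), a modest weakening that may or may not exceed the scatter.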

Compound 3, half-maximal inhibitory concentration: 25 nM
Compound 3: the middle estimate sits 4.2-fold (0.62 log units) below what was measured, and the stated range covers the measured number.
By their numbers in this assay, from the lowest: compounds 1 and 2 (each within the scatter of the next); then compound 3.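

Inverting this saturated ring carbon from S to R brings a 10-fold higher number from compound 2 to compound 3 (1.02 log units; beyond the scatter) in this assay, so this single stereocentre is a position where the read-out responds strongly to configuration. The step can be assigned to that stereocentre alone, because nothing else separates the pair: the fact that compounds 2 and 3 differ only in the configuration as drawn. Among these two compounds, the S configuration goes with the lower number, so the same atoms and bonds are not enough to keep the value in this assay.

From the compounds shown here alone, whether the inversion has a similar effect with a different group at the end of the side chain, such as a free thiol or a hydroxamic acid in place of the disulfide, remains open. Also open, going by these compounds, is how much the other stereocentres of the shared core matter.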